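Benzisoxazole-free notes: sulfonamide N-alkyl variation in a halogenated series

A few compounds are considered here, and "the series" means these few. Any claim that something is new, unique, unknown or untested is made for them only; others in the source may bear on it.

Measured so far:
compound 1 `CC(C)NS(=O)(=O)Cc1noc2ccc(F)cc12` — 38 mg/kg
compound 2 `CNS(=O)(=O)Cc1noc2ccc(Br)cc12` — 15 mg/kg

In a functional assay on the whole organism (strain STD-dd) with Mus musculus as the target, in the maximal electroshock model, with a stated time of 2 h (on this read-out lower numbers stand for an effect already at smaller amounts and higher numbers for an effect only at larger amounts of compound), compound 2 gives the lowest of the two numbers; its nearest neighbour is compound 1, which differs in two places and gives 38 mg/kg, a gap beyond the scatter. Among the compounds with values here, no single-change step between measured compounds exists. Compound 3 `CC(C)NS(=O)(=O)Cc1noc2ccc(Br)cc12` is not yet measured; it differs from compound 2 by isopropyl in place of methyl on a sulfonamide nitrogen. Within the data shown here, with no measured step for this change, a modest rise toward compound 1 is expected but not assured. Compound 3 is therefore estimated at 25 mg/kg (range 12 mg/kg to 50 mg/kg), with an expected step of a 1.7-fold higher number from compound 2 to compound 3 (0.22 log units; within the scatter).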

Compound 3, dose for half-maximal effect: 22 mg/kg
Beside the measured number, compound 3's estimate is 1.1-fold (0.06 log units) above it; the measured number falls inside the stated range.
By their numbers in this assay, from the lowest: compounds 2, 3 and 1 (each within the scatter of the next, the first and the last beyond it).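

In this assay, both single changes now readable stay within the scatter: isopropyl in place of methyl on a sulfonamide nitrogen gives a 1.5-fold higher number from compound 2 to compound 3 (0.17 log units; within the scatter), and bromo in place of fluoro on an aromatic carbon gives a 1.7-fold lower number from compound 1 to compound 3 (0.24 log units; within the scatter). At this nitrogen, methyl and isopropyl therefore cannot be told apart on this read-out in the bromo series. Neither change alone is enough to separate its pair of compounds.

On these data alone, whether a longer chain or a benzyl group on the sulfonamide nitrogen, or chloro on the aromatic carbon, would give a step beyond the scatter remains open. No supporting data bear on these small steps.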